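Aminoquinoline series: halogen pattern on the anilino ring

The source may report more compounds than this note shows. Statements on the series, on what has been measured and on what is new or still open speak of the compounds shown alone.

The series shares one core carrying a methylpiperazinyl-propoxy chain and an arylamino group, and only the aryl halogen pattern varies. Compound 1 `CN1CCN(CCCOc2cccc3nc(Nc4ccc(F)c(F)c4)ccc23)CC1` gives 5510 nM in a functional assay on NCI-H226 cells (Homo sapiens) for inhibition, read by sulforhodamine B assay, with a stated time of 48 h; a higher number here means a weaker inhibitor of growth, a lower number a stronger inhibitor of growth. Within the data shown here, compound 2 `CN1CCN(CCCOc2cccc3nc(Nc4cc(Cl)cc(Cl)c4)ccc23)CC1` gives 1950 nM in this assay, the lowest of the two numbers so far; the step of a 2.8-fold lower number from compound 1 to compound 2 (0.45 log units; beyond the scatter) is the only measured comparison and is a modest one beyond the scatter.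

Compound 3 `CN1CCN(CCCOc2cccc3nc(Nc4ccc(Cl)c(F)c4)ccc23)CC1` is not yet measured. It differs from compound 2 by 4-chloro-3-fluorophenyl in place of 3,5-dichlorophenyl on a nitrogen on an aromatic ring. Among the measured compounds shown here, the new group keeps one chlorine from compound 2 and takes one fluorine as in compound 1, so the single measured step from compound 1 to compound 2 is the only guide, and compound 3 sits between the two measured patterns. A number between the values of compound 1 and compound 2 is therefore expected for compound 3 in this assay, namely 3500 nM, with a range of 1500 nM to 8000 nM. The expected step of a 1.8-fold higher number from compound 2 to compound 3 (0.25 log units; within the scatter) would be a modest rise, possibly within the scatter.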

Compound 3, concentration for 50% growth inhibition: 2050 nM
Compound 3: the middle estimate sits 1.7-fold (0.23 log units) above what was measured; low and high end bracket the measured number.
By their numbers in this assay, from the lowest: compounds 2 and 3 (each within the scatter of the next); then compound 1.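

Replacing 3,5-dichlorophenyl with 4-chloro-3-fluorophenyl at this aryl group on the nitrogen gives a 1.1-fold higher number from compound 2 to compound 3 (0.02 log units; within the scatter) in this assay, so these two halogen patterns cannot be told apart here. The other new comparison isolates a single exchange, chloro in place of fluoro on an aromatic carbon, and gives a 2.7-fold lower number from compound 1 to compound 3 (0.43 log units; beyond the scatter), a step of the same order as a 2.8-fold lower number from compound 1 to compound 2 (0.45 log units; beyond the scatter). Among these three compounds, the 3,5-dichlorophenyl group is therefore not needed to get below the 3,4-difluorophenyl compound, since 4-chloro-3-fluorophenyl does so as well, and neither chlorine-bearing compound goes against this.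

The compounds shown leave open how an unsubstituted phenyl, a 4-chlorophenyl or a 4-bromo-3-fluorophenyl group would compare at this position, and so whether the chloro group alone sets the level in this set. They also leave open whether the step holds with a morpholine or a longer chain in place of the methylpiperazinyl-propoxy chain, and no supporting data bear on why these numbers fall as they do.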